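From acetyl to vinylcarbonyl on a shared core

The source may hold more compounds than are shown below. What is called first, only, known or untested is meant among the compounds shown, and "the series" means these compounds.

Measured in a functional assay on PANC-1 cells (Homo sapiens) for cytotoxicity, read by MTT assay, with a stated time of 24 h; on this read-out lower numbers stand for stronger inhibition and higher numbers for weaker inhibition:
Compound 1 `O=C1C=CCC(/C=C/c2ccccc2)N1`: > 100000 nM, a limit of the assay
Compound 2 `CC(=O)N1C(=O)C=CCC1/C=C/c1ccccc1`: 42300 nM
Compound 3 `COC(=O)N1C(=O)C=CCC1/C=C/c1ccccc1`: 53700 nM

Compound 2 stands at the low end of these numbers, level with its nearest neighbour within the scatter. Compound 4 `C=CC(=O)N1C(=O)C=CCC1/C=C/c1ccccc1` differs from compound 2 by vinyl in place of methyl on a carbonyl carbon. The closest measured change, methoxy in place of methyl on that same carbonyl carbon, was small: a 1.3-fold higher number from compound 2 to compound 3 (0.10 log units; within the scatter). The larger step, an at least 2.3-fold lower number from compound 1 to compound 2 (0.37 log units; beyond the scatter), was made on the amide-type nitrogen instead. No step beyond the scatter is therefore expected in this assay. The estimated step is a 1.4-fold lower number from compound 2 to compound 4 (0.15 log units; within the scatter). For compound 4 the expected value is 30000 nM, within an estimated range of 8000 nM to 60000 nM.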

Compound 4, half-maximal inhibitory concentration: 8100 nM
Compound 4: the middle estimate sits 3.7-fold (0.57 log units) above what was measured, and the stated range covers the measured number.
By their numbers in this assay, from the lowest: compound 4; then compounds 2 and 3 (each within the scatter of the next). At a limit, above all of these: compound 1.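

On this carbonyl carbon, whose other neighbour is the amide-type nitrogen in a ring, the choice of group does matter in this assay: vinyl in place of methyl gives a 5.2-fold lower number from compound 2 to compound 4 (0.72 log units; beyond the scatter), and vinyl in place of methoxy gives a 6.6-fold lower number from compound 3 to compound 4 (0.82 log units; beyond the scatter). Measured from the unsubstituted core, vinylcarbonyl in place of hydrogen gives an at least 12-fold lower number from compound 1 to compound 4 (1.09 log units; beyond the scatter). That step is only a floor, as compound 1 stands at a limit of the assay: the limit of > 100000 nM in this assay, at which 1 of the 4 values shown sits.

Ethyl, the saturated counterpart of vinyl, is not among the compounds shown, so the part played by the double bond stays open. From the compounds shown here alone, an amine on this carbonyl carbon also remains untested here.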